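Replacing Cyclohexyl with 3-Methoxyphenyl on the Ring Nitrogen

The source may report more compounds than this note shows. Statements on the series, on what has been measured and on what is new or still open speak of the compounds shown alone.

Three measured compounds share one core and differ only at an amide-type nitrogen in a ring. Compound 1 `COc1ccc(N2C(=O)COc3ccc(-c4cnc(OC)c(NS(=O)(=O)c5ccc(F)cc5)c4)cc32)cc1` bears 4-methoxyphenyl there and in a functional assay on A549 cells (Homo sapiens) for antiproliferative activity, read by MTT assay, with a stated time of 72 h (on this read-out higher numbers stand for weaker inhibition and lower numbers for stronger inhibition), compound 1 gives 1350 nM. Compound 2 `COc1ncc(-c2ccc3c(c2)N(c2ccc(F)cc2)C(=O)CO3)cc1NS(=O)(=O)c1ccc(F)cc1` carries 4-fluorophenyl, and in this assay compound 2 gives 6500 nM. Compound 3 `COc1ncc(-c2ccc3c(c2)N(C2CCCCC2)C(=O)CO3)cc1NS(=O)(=O)c1ccc(F)cc1` carries cyclohexyl, and in this assay compound 3 gives 24600 nM, the highest of the three numbers and so the weakest inhibitor here. Compound 4 `COc1cccc(N2C(=O)COc3ccc(-c4cnc(OC)c(NS(=O)(=O)c5ccc(F)cc5)c4)cc32)c1` is not yet measured and differs from compound 3 by 3-methoxyphenyl in place of cyclohexyl on an amide-type nitrogen in a ring. Going by the values given here, two steps bear on this: an 18-fold higher number from compound 1 to compound 3 (1.26 log units; beyond the scatter) and a 3.8-fold higher number from compound 2 to compound 3 (0.58 log units; beyond the scatter), both raising the number when cyclohexyl replaces 4-methoxyphenyl or 4-fluorophenyl. Running the other way, compound 4 is expected to show a 9.8-fold lower number from compound 3 to compound 4 (0.99 log units; beyond the scatter). The estimate for compound 4 is 2500 nM, within 800 nM to 8000 nM.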

Compound 4, half-maximal inhibitory concentration: 11200 nM
Compound 4: middle estimate off by 4.5-fold (0.65 log units), on the low side, and the stated range ends below it.
By their numbers in this assay, from the lowest: compound 1; then compounds 2 and 4 (each within the scatter of the next); then compound 3.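

In this assay, 3-methoxyphenyl in place of cyclohexyl gives only a 2.2-fold lower number from compound 3 to compound 4 (0.34 log units; beyond the scatter) and so an aromatic ring on this nitrogen does not by itself reach the level of compound 1. Where the methoxy group sits on the phenyl ring matters, with an 8.3-fold higher number from compound 1 to compound 4 (0.92 log units; beyond the scatter) on going from 4-methoxyphenyl to 3-methoxyphenyl, while a 1.7-fold higher number from compound 2 to compound 4 (0.24 log units; within the scatter) shows that 3-methoxyphenyl and 4-fluorophenyl cannot be told apart here. Nothing measured here gives a reason for these differences. The compounds shown leave open how an amine or a carboxylic acid on this phenyl ring, or a plain methyl on the ring nitrogen, would compare.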